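Swapping the Pyrazolyl Group on the Amide Nitrogen

This account rests on a few compounds, and the source may have more. Where it says the series, first, only, none or still open, it means among the compounds named here.

Three compounds have so far been measured in an assay on HEK293 cells for agonist activity at transient receptor potential cation channel subfamily M member 8 (Homo sapiens), read by fluorescence and calcium flux, with a stated time of 15 min; a lower number here means that less compound is needed, a higher number that more compound is needed for the effect:

Compound 1 `Cc1ccc(OCC(=O)N(Cc2cccs2)c2ccn[nH]2)cc1`: 0.2 nM
Compound 2 `COc1ccc(OCC(=O)N(Cc2cccs2)c2ccn[nH]2)cc1`: 3.7 nM
Compound 3 `CCN(Cc1cccnc1)C(=O)COc1ccc(C)cc1`: 15400 nM

Compound 1 gives the lowest number of the three, so the least of it is needed for the effect. Its nearest neighbour is compound 2, reached by a single change, methoxy in place of methyl on an aromatic carbon, which brings a 19-fold higher number from compound 1 to compound 2 (1.27 log units; beyond the scatter). Compound 3 lies very far away, but it differs from compound 1 in more than one place, so the two values show only that the gap is wide, not which change causes it.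

Compound 4 `CON(Cc1cccs1)C(=O)COc1ccc(C)cc1` has not yet been measured. It differs from compound 1 in one place: methoxy in place of 1H-pyrazol-5-yl on an amide-type nitrogen. Within the data shown here, no measured step isolates this change; the only step available concerns a substituent on the aromatic ring and says nothing about the amide nitrogen. Among the measured compounds shown here, compound 3 is the one compound without the 1H-pyrazol-5-yl group, and compound 3 gives 15400 nM, though with further differences. A large step upward is therefore expected, a 15000-fold higher number from compound 1 to compound 4 (4.18 log units; beyond the scatter). Compound 4 is estimated to give 3000 nM, within a range from 200 nM to 40000 nM.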

Compound 4, half-maximal effective concentration: 10 nM
The estimate for compound 4 lay 300-fold (2.48 log units) above the measured number; measured number outside the range, below it.
By their numbers in this assay, from the lowest: compound 1; then compound 2; then compound 4; then compound 3.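

In this assay, among these compounds, putting methoxy in place of 1H-pyrazol-5-yl on the amide-type nitrogen brings a 50-fold higher number from compound 1 to compound 4 (1.70 log units; beyond the scatter), and this is the first measured step that isolates a change at this position. The group on this nitrogen therefore clearly affects how much compound is needed, yet the five-membered aromatic ring is not essential for a low number: compound 4 gives 10 nM with no ring at this place, 0 hydrogen-bond donors in the entering group and fewer heavy atoms. No measurement here explains the size of the step or shows whether it follows from losing the ring, the hydrogen-bond donor or the larger group as a whole.

As far as these compounds go, a single replacement cannot separate these differences, so it remains open how a phenyl ring, which would keep a ring but carry no hydrogen-bond donor, or a longer ethoxy chain would behave on this nitrogen. Also open, from the compounds shown here alone, is whether methoxy in place of methyl on the aromatic carbon would bring a similar step when the nitrogen carries methoxy rather than 1H-pyrazol-5-yl.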